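This account rests on a few compounds, and the source may have more. Where it says the series, first, only, none or still open, it means among the compounds named here.

Working notes on the series. For the measured compounds named here, compound 1 `CCCC(=O)N1CC2CC(C1)N2` is the reference point; in an assay on SH-EP1 cells for agonist activity at Neuronal acetylcholine receptor; alpha4/beta2 (Homo sapiens), read by FLIPR and calcium flux (on this read-out higher numbers stand for an effect only at larger amounts of compound and lower numbers for an effect already at smaller amounts), compound 1 gives 850 nM, the lowest of the two numbers measured so far. Its nearest neighbour, compound 2 `O=C([C@H]1C[C@@H]1F)N1CC2CC(C1)N2`, gives 2800 nM in this assay. Compound 3 `O=C([C@@H]1C[C@H]1F)N1CC2CC(C1)N2` is still to be measured in this assay. Relative to compound 1 the change is 2-fluorocyclopropyl in place of propyl on a carbonyl carbon. The entering group is the same 2-fluorocyclopropyl found in compound 2, carried with the opposite configuration at both of its stereocentres. Going by the values given here, the only measured step that bears on this change is a 3.3-fold higher number from compound 1 to compound 2 (0.52 log units; beyond the scatter), modest but beyond the scatter. Among the compounds with values here, a step of similar size and direction is expected for compound 3, a 2.6-fold higher number from compound 1 to compound 3 (0.41 log units; beyond the scatter), though with wide uncertainty, as only one configuration of the group has been measured. For compound 3 the estimate in this assay is 2200 nM, with a range of 600 nM to 8000 nM.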

Compound 3, half-maximal effective concentration: 870 nM
Compound 3: middle estimate off by 2.5-fold (0.40 log units), on the high side; the measured number falls inside the stated range.
By their numbers in this assay, from the lowest: compounds 1 and 3 (each within the scatter of the next); then compound 2.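

In this assay, 2-fluorocyclopropyl on the carbonyl carbon can stand in place of propyl with no reading change, the step being a 1.0-fold higher number from compound 1 to compound 3 (0.01 log units; within the scatter). The loss seen earlier therefore belongs to one configuration of the group and not to the group as such, the stereo pair showing a 3.2-fold lower number from compound 2 to compound 3 (0.51 log units; beyond the scatter). This position thus tells the two configurations apart, with one reservation on that pair: the fact that one of compounds 2 and 3 is drawn with a defined configuration and the other without, at the place where they differ.

Still open, from the compounds shown here alone, is whether plain cyclopropyl without the fluorine, or a longer chain on the same carbonyl carbon, would read with compounds 1 and 3 or with compound 2. Also open, going by these compounds, is whether the gap between the two configurations would persist with chlorine in place of the fluorine.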